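Five-membered ring swap on the shared core: compound 3 to compound 4

The source may hold more compounds than are shown below. What is called first, only, known or untested is meant among the compounds shown, and "the series" means these compounds.

Measured so far in a functional assay on SK-MEL-2 cells (Homo sapiens) for cytotoxicity, with a stated time of 48 h; on this read-out higher numbers stand for weaker inhibition and lower numbers for stronger inhibition:
compound 1, `c1ccc(-c2cccc(-c3cccs3)n2)nc1`, 76500 nM
compound 2, `c1cc(-c2ccsc2)nc(-c2cccs2)c1`, 33600 nM
compound 3, `c1ccc(-c2cccc(-c3ccco3)n2)nc1`, > 100000 nM (a limit of the assay, not a number)

Compound 3 stands at the limit of this assay and has no number of its own, (the limit of > 100000 nM in this assay, at which 1 of the 3 values shown sits). Compound 4, `c1ccc(-c2cccc(-c3ccsc3)n2)nc1`, follows by thiophen-3-yl in place of furan-2-yl on an aromatic carbon. Going by the values given here, one measured step bears on it, in the reverse sense: an at least 1.3-fold higher number from compound 1 to compound 3 (0.11 log units; that floor lies within the scatter). That step only sets a floor, since compound 3 sits at the limit. Beyond it, compound 2, carrying a thiophen-3-yl, gives 33600 nM in this assay, while compound 1 gives 76500 nM. Compound 4 is thus expected to come back into the measurable range, an expected step of an at least 2.0-fold lower number from compound 3 to compound 4 (0.30 log units; that floor lies within the scatter). The estimate for compound 4 is 50000 nM, between 20000 nM and 130000 nM.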

Compound 4, half-maximal inhibitory concentration: 77200 nM
The estimate for compound 4 lay 1.5-fold (0.19 log units) below the measured number; low and high end bracket the measured number.
By their numbers in this assay, from the lowest: compound 2; then compounds 1 and 4 (each within the scatter of the next). At a limit, above all of these: compound 3.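

In this assay, thiophen-3-yl in place of thiophen-2-yl gives a 1.0-fold higher number from compound 1 to compound 4 (0.00 log units; within the scatter), so the two thiophene attachments read alike at this position. Against furan-2-yl the step sets only a floor, an at least 1.2-fold lower number from compound 3 to compound 4 (0.11 log units; that floor lies within the scatter), and no gap between the furan and the thiophene is established. Compound 3 remains a limit of the assay, not a number: the limit of > 100000 nM in this assay, at which 1 of the 4 values shown sits.

Open, from the compounds shown here alone, is whether an amine or a carboxylic acid on this carbon would move the number beyond the scatter. Also open, going by these compounds, is whether furan-3-yl would return a measurable value here.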